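Amino substituent variation on the shared quinazoline-like core

The source may report more compounds than this note shows. Statements on the series, on what has been measured and on what is new or still open speak of the compounds shown alone.

Measured so far in a functional assay on HCT-116 cells (Homo sapiens) for inhibition, read by luminescence and resazurin assay, with a stated time of 3 days; a lower number here means a stronger inhibitor, a higher number a weaker inhibitor:
compound 1, `O=C(Nc1ccc(F)cc1)c1ccc(CNc2nc(NC3CC3)nc3ccccc23)cc1`: 2700 nM
compound 2, `CCCNc1nc(NCc2ccc(C(=O)Nc3ccc(F)cc3)cc2)c2ccccc2n1`: 1500 nM
compound 3, `CN(C)c1nc(NCc2ccc(C(=O)Nc3ccc(F)cc3)cc2)c2ccccc2n1`: 1900 nM

Compound 3 sits with the other two inside the usual scatter: a 1.3-fold higher number from compound 2 to compound 3 (0.10 log units; within the scatter) and a 1.4-fold lower number from compound 1 to compound 3 (0.15 log units; within the scatter) are both within the scatter, as is a 1.8-fold lower number from compound 1 to compound 2 (0.26 log units; within the scatter). None of the three replacements at this position has moved this assay beyond the noise of the measurement, and no ordering among compounds 1, 2 and 3 can be read from these numbers.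

Compound 4, `CC1CN(c2nc(NCc3ccc(C(=O)Nc4ccc(F)cc4)cc3)c3ccccc3n2)CCN1`, continues the same exchange: 3-methylpiperazin-1-yl in place of dimethylamino on an aromatic carbon. Among the compounds with values here, the group entering is larger than any of the three tried so far and brings a ring and a hydrogen-bond donor, for which the series holds no precedent. Within the data shown here, the only steps that bear on it are the three above, all within the scatter, so the expectation is a step that again stays within the scatter, with no direction given; the estimated step is a 1.2-fold lower number from compound 3 to compound 4 (0.07 log units; within the scatter). Compound 4 is therefore expected to give about 1600 nM, with a range from 500 nM to 5000 nM to cover the untested ring.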

Compound 4, half-maximal inhibitory concentration: 2800 nM
Beside the measured number, compound 4's estimate is 1.8-fold (0.24 log units) below it; low and high end bracket the measured number.
By their numbers in this assay, from the lowest: compounds 2, 3, 1 and 4 (each within the scatter of the next).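

In this assay, within the data shown here, 3-methylpiperazin-1-yl, the first group at this position with a six-membered non-aromatic ring and a hydrogen-bond donor, stays within the scatter of all three earlier compounds (a 1.5-fold higher number from compound 3 to compound 4 (0.17 log units; within the scatter); a 1.9-fold higher number from compound 2 to compound 4 (0.27 log units; within the scatter); a 1.0-fold higher number from compound 1 to compound 4 (0.02 log units; within the scatter)). The aromatic carbon between two ring nitrogen atoms therefore accepts this larger ring in place of the smaller amino groups with no step beyond the scatter, and the four compounds can be read as one level with no ordering among them. No measurement at hand accounts for this flat result.

Still open, as far as these compounds go, is whether any group at this position can move the number beyond the scatter, for example a morpholine ring, an aniline or a longer chain ending in a carboxylic acid. The compounds shown also leave open whether the piperazine ring without its methyl group would read the same.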